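Dropping a Fluorine from the Larger Triazole Sulfonamide

The compounds below may be only part of what the source reports. "The series", "measured", "known", "first", "only" and "open" are said of these compounds alone.

Of the compounds shown here, two have so far been measured in a functional assay on 3T3-L1 cells (Mus musculus) for inhibition, with a stated time of 20 min, tested at 20 uM; a lower number here means less inhibition, a higher number more inhibition at the concentration tested (going by the name of the read-out). Compound 1 `CC(=O)N(Cc1cn(Cc2cccc(F)c2F)nn1)Cc1cn(S(=O)(=O)c2ccc(C)cc2)c2ccccc12` gives 39.5% in this assay. Compound 2 `Cc1ccc(S(=O)(=O)N(Cc2cn(Cc3ccc(F)cc3)nn2)Cc2c(-c3ccccc3)c3ccccc3n2S(=O)(=O)c2ccc(C)cc2)cc1` gives -7.6% in this assay, the lower of the two numbers; the only other measured compound, compound 1, sits higher by a margin beyond the usual scatter, so the inhibition of compound 2 in this assay is the lower of the pair on the numbers shown.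

Compound 3 `Cc1ccc(S(=O)(=O)N(Cc2cn(Cc3ccccc3)nn2)Cc2c(-c3ccccc3)c3ccccc3n2S(=O)(=O)c2ccc(C)cc2)cc1` has not yet been measured. It differs from compound 2 in a single place: hydrogen in place of fluoro on an aromatic carbon. Cut one bond further out, the change reads 4-fluorophenyl to phenyl, a fluoro leaving and a hydrogen entering on an aromatic carbon of a six-membered aromatic ring of carbon only. For the measured compounds named here, no step between measured compounds is available to calibrate such a change, so the expectation rests on the small size of the difference alone. The step from compound 2 to compound 3 is expected to be a number 7.6 percentage points higher from compound 2 to compound 3 (within the scatter), in neither direction beyond the scatter. Compound 3 is therefore estimated at 0%, with a range from -15% to 15%.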

Compound 3, a percentage reported as inhibition, at one concentration (the size of the read-out at that concentration, not a potency): 0.03%
Compound 3: the middle estimate sits 0 percentage points below what was measured; measured number inside the range.
By their numbers in this assay, from the lowest: compounds 2 and 3 (each within the scatter of the next); then compound 1.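

In this assay, replacing fluoro with hydrogen on an aromatic carbon, para to a large group, gives a number 7.6 percentage points higher from compound 2 to compound 3 (within the scatter). For the compounds shown here, this is the first step here that isolates a single place, and it shows that taking 4-fluorobenzyl to benzyl on the triazole of this larger sulfonamide does not separate the two compounds on this read-out; with both values lying close to zero, the fluoro cannot be credited with any measurable contribution to inhibition. The compounds offer nothing that would explain this result, so it stands as an observation only.

What remains open is whether this position responds at all to a group that differs more from hydrogen than fluoro does, such as an amine, a carboxylic acid or a methoxy group, since only hydrogen and fluoro are shown there. Also open, going by these compounds, is whether the same exchange would stay within the scatter on a compound with clearer inhibition, such as compound 1, whose core and other substituents differ in more than one place and so cannot be read against this step.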